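Adding a Bromo Group: Cytotoxicity of Four Amides

The compounds below may be only part of what the source reports. "The series", "measured", "known", "first", "only" and "open" are said of these compounds alone.

Compound 1, `O=C(Nc1cccc(Cl)c1)c1cc(Br)cc(Br)c1`: 53000 nM
Compound 2, `O=C(Nc1cccc(Cl)c1)c1cccc(Br)c1`: 51000 nM
Compound 3, `O=C(Nc1ccc(Sc2nc3ccccc3s2)cc1)c1ccccc1O`: 74000 nM

All three were tested in an ADME assay on HEK293 cells (Homo sapiens) for cytotoxicity, read by reporter gene assay and resazurin assay, with a stated time of 48 h; on this read-out lower numbers stand for higher toxicity in this test and higher numbers for lower toxicity in this test. Their three numbers lie within the usual scatter of one another, so none of them can be called more or less toxic than the others. Compound 4, `O=C(Nc1ccc(Sc2nc3ccccc3s2)cc1)c1cccc(Br)c1O`, has not been measured. It differs from compound 3 by bromo in place of hydrogen on an aromatic carbon. The same kind of change, (bromo in place of hydrogen on an aromatic carbon), links compound 2 to compound 1, where it gave a 1.0-fold higher number from compound 2 to compound 1 (0.02 log units; within the scatter). The surroundings differ: in compound 4 the new group sits ortho to a hydroxy group and meta to a large group, while in compound 1 it sits meta to a bromo group and meta to a large group. How the core of compound 3 differs from that of compound 2 is not broken down here. In this assay the step from compound 3 to compound 4 is expected to be a 1.1-fold lower number from compound 3 to compound 4 (0.02 log units; within the scatter), because the earlier one was a 1.0-fold higher number from compound 2 to compound 1 (0.02 log units; within the scatter). Compound 4 is therefore estimated at 70000 nM, within 30000 nM to 150000 nM.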

Compound 4, half-maximal cytotoxic concentration: 71000 nM
The estimate for compound 4 lay 1.0-fold (0.01 log units) below the measured number; the measured number falls inside the stated range.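

In this assay, putting a bromo group in place of a hydrogen on an aromatic carbon of compound 3 gave a 1.0-fold lower number from compound 3 to compound 4 (0.02 log units; within the scatter). Set beside the earlier case, the same change behaved alike on the two cores, as far as this test can tell: the same change on two cores in this assay, a 1.0-fold higher number (0.02 log units; within the scatter) from compound 2 to compound 1 and a 1.0-fold lower number (0.02 log units; within the scatter) from compound 3 to compound 4, 1.1-fold (0.03 log units) apart, within the scatter of two such steps This shows that in both pairs the change left the number within the usual scatter, whether the bromo group sat ortho to a hydroxy group, as in compound 4, or elsewhere, but two pairs make no general rule, and they do not show that a bromo group would leave the number unmoved on other cores or at other places on the ring.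

The compounds shown leave open whether another group at the same place, such as an amine, a carboxylic acid or a longer alkyl chain, would move the number beyond the scatter. They also leave open how the bromo group would fare on a core of compound 4 with a methoxy group in place of the hydroxy group.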